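This account rests on a few compounds, and the source may have more. Where it says the series, first, only, none or still open, it means among the compounds named here.

Of the compounds shown here, three have been measured in a functional assay on OVCAR-4 cells (Homo sapiens) for inhibition, read by sulforhodamine B assay, with a stated time of 48 h, tested at 10 uM; on this read-out higher numbers stand for more inhibition at the one concentration tested (going by the name of the read-out) and lower numbers for less inhibition. Compound 1 `Brc1cn2ccnc2c(-c2ccc3ncn(C4CCCCC4)c3c2)n1` gives 9.15%, compound 2 `O=Cc1ccc(-c2cn3ccnc3c(-c3ccc4ncn(C5CCCCC5)c4c3)n2)cc1` gives 16.9%, and compound 3 `CCc1ccc(-c2cn3ccnc3c(-c3ccc4ncn(Cc5ccccc5)c4c3)n2)cc1` gives 35.1%. For the measured compounds named here, the one measured step, a number 7.8 percentage points higher from compound 1 to compound 2 (within the scatter), is within the scatter. Compound 3 stands highest of the three: compound 2 lies nearest, a gap beyond the scatter, and compound 1 lies furthest, also beyond the scatter.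

Compound 4 `O=Cc1ccc(-c2cn3ccnc3c(-c3ccc4ncn(Cc5ccccc5)c4c3)n2)cc1` is not yet measured. Compared with compound 3 the change is formyl in place of ethyl on an aromatic carbon. Going by the values given here, no measured step swaps ethyl for formyl, so the expectation rests on weaker footing: compound 2, which also carries the 4-formylphenyl group, gives 16.9%, well under compound 3, while the step of a number 7.8 percentage points higher from compound 1 to compound 2 (within the scatter) shows formylphenyl bringing only a small gain where it entered. For compound 4 a step of a number 11.1 percentage points lower from compound 3 to compound 4 (beyond the scatter) in this assay is therefore expected, a modest fall that may still lie within the scatter. Compound 4 is estimated at 24%, within a range of 9% to 40%.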

Compound 4, a percentage reported as inhibition, at one concentration (the size of the read-out at that concentration, not a potency): 16.9%
For compound 4 the middle estimate is 7.1 percentage points above the measured one; the range from low to high includes it.
By their numbers in this assay, from the lowest: compounds 1, 2 and 4 (each within the scatter of the next); then compound 3.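

Placing 4-formylphenyl where 4-ethylphenyl stood gives the first direct comparison at this position: in this assay, the swap of ethyl for formyl gives a number 18.2 percentage points lower from compound 3 to compound 4 (beyond the scatter), so this small group on the outer aromatic ring matters when the benzyl group is present. With formyl held constant, benzyl in place of cyclohexyl on the aromatic nitrogen gives no change at the digits printed from compound 2 to compound 4 (within the scatter), so this pair shows no readable effect of that swap. Nothing available explains why ethyl and formyl differ in this way.

On these data alone, it remains open whether the difference between ethyl and formyl would also appear with cyclohexyl on the nitrogen. As far as these compounds go, it is also open how an amine, a carboxylic acid or a longer chain such as propyl would read at this same place.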